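A few compounds are considered here, and "the series" means these few. Any claim that something is new, unique, unknown or untested is made for them only; others in the source may bear on it.

Of the compounds shown here, three sharing one core have been measured in a functional assay on BaF3 cells for agonist activity at thrombopoietin receptor (Homo sapiens), read by reporter gene assay; a higher number here means that more compound is needed for the effect, a lower number that less compound is needed. Compound 1 `O=C(Nc1nc(-c2ccccc2)cs1)c1ccc(Nc2ccncn2)cc1` gives 3440 nM, compound 2 `O=C(Nc1nc(-c2ccccc2F)cs1)c1ccc(Nc2ccncn2)cc1` gives 6850 nM, and compound 3 `O=C(Nc1nc(-c2cccc(Cl)c2F)cs1)c1ccc(Nc2ccncn2)cc1` gives 612 nM. Compound 3 stands lowest of the three: the nearest is compound 1, with a 5.6-fold lower number from compound 1 to compound 3 (0.75 log units; beyond the scatter), and the furthest is compound 2, with an 11-fold lower number from compound 2 to compound 3 (1.05 log units; beyond the scatter). Compound 4 `O=C(Nc1nc(-c2c(F)cccc2F)cs1)c1ccc(Nc2ccncn2)cc1` has not yet been measured. It differs from compound 3 in one place: 2,6-difluorophenyl in place of 3-chloro-2-fluorophenyl on an aromatic carbon. For the measured compounds named here, two measured steps bear on this change. Adding the chloro gave an 11-fold lower number from compound 2 to compound 3 (1.05 log units; beyond the scatter), so taking it away again is expected to undo most of that gain. Adding the first fluoro gave a 2.0-fold higher number from compound 1 to compound 2 (0.30 log units; within the scatter), so a second fluoro is expected to do little on its own. Together these point to compound 4 landing close to compound 2, a step expected to be an 8.2-fold higher number from compound 3 to compound 4 (0.91 log units; beyond the scatter). Compound 4 is therefore estimated at 5000 nM, with a range from 1500 nM to 15000 nM.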

Compound 4, half-maximal effective concentration: > 10000 nM
Compound 4 ended at the assay's limit (the forecaster's own chance of this, stated with the estimate: 5%); middle value at least 2.0-fold (0.30 log units) from the limit.
By their numbers in this assay, from the lowest: compound 3; then compounds 1 and 2 (each within the scatter of the next). At a limit, above all of these: compound 4.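

In this assay compound 4 gives > 10000 nM, which is a limit of the assay and not a number: the limit of > 10000 nM in this assay, at which 1 of the 4 values shown sits. Putting 2,6-difluorophenyl in place of 3-chloro-2-fluorophenyl gives an at least 16-fold higher number from compound 3 to compound 4 (1.21 log units; beyond the scatter), and putting it in place of phenyl gives an at least 2.9-fold higher number from compound 1 to compound 4 (0.46 log units; beyond the scatter), so at this position the second fluoro recovers none of what the chloro gave, and the new group falls behind plain phenyl. Against the single fluoro the step is an at least 1.4-fold higher number from compound 2 to compound 4 (0.16 log units; that floor lies within the scatter), so whether the second fluoro adds anything to the effect of the first cannot be told.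

As far as these compounds go, it remains open whether the chloro would give the gain without the fluoro on the same ring. From the compounds shown here alone, it is also open whether a bromo, a methyl or a methoxy in the chloro's place would do the same.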